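The source may hold more compounds than are shown below. What is called first, only, known or untested is meant among the compounds shown, and "the series" means these compounds.

Of the compounds shown here, three sharing one core have so far been measured in a functional assay on T98G cells (Homo sapiens) for inhibition, read by MTT assay, with a stated time of 72 h; a lower number here means a stronger inhibitor, a higher number a weaker inhibitor. Compound 1 `CC1(C)CC(NC(=S)Nc2cccc(C#N)c2)c2cc(Br)ccc2O1` gives 9000 nM, the highest number of the three and so the weakest inhibitor among them. Compound 2 `CC1(C)CC(NC(=S)Nc2cccc([N+](=O)[O-])c2)c2cc(Br)ccc2O1` gives 4000 nM, and compound 3 `CC1(C)CC(NC(=S)Nc2ccc([N+](=O)[O-])cc2)c2cc(Cl)ccc2O1` gives 4000 nM. Among the compounds with values here, only one pair differs in a single place, and that step is a 2.3-fold lower number from compound 1 to compound 2 (0.35 log units; beyond the scatter).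

Compound 4 `CC1(C)CC(NC(=S)Nc2ccc(C#N)cc2)c2cc(Br)ccc2O1` is derived from compound 1 by the change (4-cyanophenyl in place of 3-cyanophenyl on an amide-type nitrogen). The two compounds contain the same atoms joined differently, so this is a rearrangement rather than an exchange of groups. Within the data shown here, no measured step isolates such a rearrangement: compound 2 and compound 3 differ from each other in two places at once, and the two simply give the same number. Among the measured compounds shown here, the single measured step, a 2.3-fold lower number from compound 1 to compound 2 (0.35 log units; beyond the scatter), concerns swapping one group for another and so bears on compound 4 only loosely, giving no direction for the present change. The expectation for compound 4 is therefore a step of a 1.3-fold lower number from compound 1 to compound 4 (0.11 log units; within the scatter), which would stay within the scatter of repeated measurements. Compound 4 is estimated at 7000 nM, with a likely range from 3000 nM to 18000 nM.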

Compound 4, half-maximal inhibitory concentration: 24000 nM
The estimate for compound 4 lay 3.4-fold (0.54 log units) below the measured number; the whole stated range lies below it.
By their numbers in this assay, from the lowest: compounds 2 and 3 (each within the scatter of the next); then compound 1; then compound 4.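

Within the data shown here, the earlier compounds showed only one group exchanged for another, whereas this step shows that rearranging the same atoms can also shift the result. In this assay, 4-cyanophenyl in place of 3-cyanophenyl on the amide-type nitrogen gives a 2.7-fold higher number from compound 1 to compound 4 (0.43 log units; beyond the scatter), a step beyond the usual scatter and towards weaker inhibition, even though the counts of atoms, rings and hydrogen-bond groups stay the same. Nothing measured here accounts for this difference, and the result records only its direction and size for this one pair.

Compound 2 and compound 3 differ in two places at once, which leaves open whether a nitro group responds to the same rearrangement as the nitrile does. Also open, from the compounds shown here alone, is how the number would move with an amine or a carboxylic acid on the aromatic ring attached to this nitrogen.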